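Compound 4: one more methyl past an assay limit

The source may hold more compounds than are shown below. What is called first, only, known or untested is meant among the compounds shown, and "the series" means these compounds.

Compound 1 `C/N=C(/NC#N)C1=CC(C)(C)Oc2ccc([N+](=O)[O-])cc21` gives 15.1 nM
Compound 2 `CN(C)/C(=N\C#N)C1=CC(C)(C)Oc2ccc([N+](=O)[O-])cc21` gives < 31700 nM, a limit of the assay
Compound 3 `CCN(C)/C(=N\C#N)C1=CC(C)(C)Oc2ccc([N+](=O)[O-])cc21` gives < 31700 nM, a limit of the assay

These values come from a functional assay (aorta) with Rattus norvegicus as the target; a higher number here means that more compound is needed for the effect, a lower number that less compound is needed. Compound 3 has no exact number there, only the limit < 31700 nM. It is not alone in this, as the record shows (the limit of < 31700 nM in this assay, at which 2 of the 3 values shown sit). Going by these compounds, its exact place on the scale therefore stays open.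

Compound 4 `CCN(CC)/C(=N\C#N)C1=CC(C)(C)Oc2ccc([N+](=O)[O-])cc21` has not been measured yet. It turns the ethyl(methyl)amino group of compound 3 into diethylamino, a change of methyl to ethyl: methyl in place of hydrogen on a saturated chain carbon bound to an amine nitrogen.

Among the measured compounds shown here, two measured steps bear on this. The closest is a step that the two limits leave unreadable from compound 2 to compound 3, which is the same swap of methyl for hydrogen on a saturated chain carbon bound to an amine nitrogen. The other is a step that the limit leaves unreadable from compound 1 to compound 2, a different change that says less about this one. Neither step has a readable size, so neither supports a step in a particular direction. Another limit in this assay is the likeliest result for compound 4 because of the limit of < 31700 nM in this assay, at which 2 of the 3 values shown sit.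

The estimated step is a step that the limit leaves unreadable from compound 3 to compound 4. For compound 4 the expected value is 20000 nM, with an estimated range from 3000 nM to 35000 nM.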

Compound 4, half-maximal effective concentration: < 31700 nM
Compound 4: no number, only a limit; the forecaster's own chance of this, stated with the estimate: 85%; the middle value does not contradict the limit.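

In this assay compound 4 gives < 31700 nM, a limit of the assay and not a number, so no new step can be read from compound 2 or compound 3 to compound 4. The same limit recurs across the series: the limit of < 31700 nM in this assay, at which 3 of the 4 values shown sit.

The compounds shown leave open where compound 2, compound 3 and compound 4 truly stand relative to one another.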